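The compounds below may be only part of what the source reports. "The series", "measured", "known", "first", "only" and "open" are said of these compounds alone.

In a functional assay on A549 cells (Homo sapiens) for cytotoxicity, read by MTT assay, with a stated time of 72 h (on this read-out lower numbers stand for stronger inhibition and higher numbers for weaker inhibition), compound 1 (`CC1=CCC[C@H]2[C@](C)(CC3=CC(=O)C=C(N[C@@H](CC(C)C)C(=O)O)C3=O)[C@@H](C)CC[C@]12C`) gives 19700 nM. Compound 2 (`CC(C)(C)C1=CC(=O)C=C(NCCC(=O)O)C1=O`) gives 171000 nM in this assay. Of these two numbers, that of compound 1 is the lower one, and the gap to compound 2 is beyond the usual scatter of this kind of measurement, so compound 1 shows the stronger inhibition of the pair. For the measured compounds named here, no step between compounds that differ in only one place is available here, so the two values can only be compared as they stand.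

Compound 3 (`CC1=CCC[C@H]2[C@](C)(CC3=CC(=O)C=CC3=O)[C@@H](C)CC[C@]12C`) has not yet been measured in this assay. It is obtained from compound 1 by the change (hydrogen in place of (1-carboxy-3-methylbutyl)amino on a double-bonded ring carbon). The (1-carboxy-3-methylbutyl)amino group is thus removed and only a hydrogen remains on that double-bonded ring carbon, while the rest of compound 1, including its large hydrocarbon portion, stays in place.

Because compound 1 already gives 19700 nM, the expected step of a 3.9-fold lower number from compound 1 to compound 3 (0.60 log units; beyond the scatter) is one towards a lower number, estimated as moderate in size. Compound 3 is therefore expected to give about 5000 nM in this assay, within a range from 1200 nM to 20000 nM.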

Compound 3, half-maximal inhibitory concentration: 30000 nM
For compound 3 the middle estimate is 6.0-fold (0.78 log units) below the measured one; measured number outside the range, above it.
By their numbers in this assay, from the lowest: compounds 1 and 3 (each within the scatter of the next); then compound 2.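

Taking the (1-carboxy-3-methylbutyl)amino group off the double-bonded ring carbon and leaving only hydrogen gives a 1.5-fold higher number from compound 1 to compound 3 (0.18 log units; within the scatter) in this assay. For the compounds shown here, this is the first comparison in which a single place changes, and it shows that compound 1 and compound 3 cannot be told apart in this assay, even though a sizeable group with a carboxylic acid and a defined stereocentre is gone. At this position, then, the number does not depend on that group, although no measurement shown here accounts for this.

From the compounds shown here alone, it remains open whether a plain amine on the same ring carbon, or a longer chain ending in a carboxylic acid, would also give a number of this size. Only hydrogen and one amino-linked group are compared here, so this pair shows no trend across groups at this position, and as the large hydrocarbon portion is the same in compound 1 and compound 3, its share in their values cannot be read from them.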